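The source may report more compounds than this note shows. Statements on the series, on what has been measured and on what is new or still open speak of the compounds shown alone.

Three compounds have been measured in an assay on FRT-Jurkat cells for inhibition of nuclear factor NF-kappa-B complex (Homo sapiens), read by flow cytometry, with a stated time of 24 h, tested at 10 uM; on this read-out higher numbers stand for more inhibition at the one concentration tested (going by the name of the read-out) and lower numbers for less inhibition:

- compound 1, `O=C1CCC(N2C(=O)c3cccc(Nc4ccccn4)c3C2=O)C(=O)N1`, gives 1%
- compound 2, `COc1ccc(Nc2cccc3c2C(=O)N(C2CCC(=O)NC2=O)C3=O)cc1`, gives 13%
- compound 3, `Cc1ccccc1Nc1cccc2c1C(=O)N(C1CCC(=O)NC1=O)C2=O`, gives 7%

Compound 3 stands second highest of these three numbers. Its nearest neighbour is compound 1, and the step of a number 6 percentage points higher from compound 1 to compound 3 (within the scatter) lies within the scatter; the step of a number 6 percentage points lower from compound 2 to compound 3 (within the scatter) lies within the scatter as well, so none of the three numbers can be said to be higher or lower than that of compound 3. Among the compounds with values here, only the step of a number 12 percentage points higher from compound 1 to compound 2 (beyond the scatter) is beyond the scatter, and it is modest.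

Compound 4, `CC(C)(C)c1ccc(Nc2cccc3c2C(=O)N(C2CCC(=O)NC2=O)C3=O)cc1`, differs from compound 3 in one place: 4-(tert-butyl)phenyl in place of 2-methylphenyl on a nitrogen on an aromatic ring. All three measured steps change the group on that same nitrogen, and two of them stayed within the scatter while the third was modest. The expectation for this change is therefore a step of a number 2 percentage points higher from compound 3 to compound 4 (within the scatter), not clearly beyond the scatter. Compound 4 is estimated to give 9%, with a range from 0% to 22%.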

Compound 4, a percentage reported as inhibition, at one concentration (the size of the read-out at that concentration, not a potency): 36%
For compound 4 the middle estimate is 27 percentage points below the measured one; the whole stated range lies below it.
By their numbers in this assay, from the lowest: compounds 1, 3 and 2 (each within the scatter of the next, the first and the last beyond it); then compound 4.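

In this assay the group on this nitrogen matters more than the first three compounds suggested: 4-(tert-butyl)phenyl gives a number 29 percentage points higher from compound 3 to compound 4 (beyond the scatter) and also a number 35 percentage points higher from compound 1 to compound 4 (beyond the scatter), a large step, which no earlier change there produced. The most telling comparison keeps the phenyl ring and changes only the group on an aromatic carbon, tert-butyl in place of methoxy, and it gives a number 23 percentage points higher from compound 2 to compound 4 (beyond the scatter), so a phenyl ring alone does not set the number. Nothing measured here explains why tert-butyl has this effect.

Still open, on these data alone, is whether an amine, a carboxylic acid or a longer alkyl chain on that phenyl ring would match compound 4 or fall back towards the other compounds. A reading at one concentration also leaves the potency of compound 4 unknown.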